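Swapping a chloro for a methoxy on the aryl ring

The source may hold more compounds than are shown below. What is called first, only, known or untested is meant among the compounds shown, and "the series" means these compounds.

Compound 2 `Cn1nccc1C(=O)Nc1ccc(-c2cc(Cl)ccc2Cl)c(N)n1` gives 920 nM in an assay on HEK293 cells for inhibition of sodium channel protein type 10 subunit alpha (Homo sapiens), read by fluorescence (on this read-out higher numbers stand for weaker inhibition and lower numbers for stronger inhibition), and compound 1 `Cn1nccc1C(=O)Nc1ccc(-c2cc(Cl)cc(Cl)c2Cl)c(N)n1` gives 750 nM, the two within the scatter of each other. Among the compounds with values here, the only step measured so far, a 1.2-fold higher number from compound 1 to compound 2 (0.09 log units; within the scatter), removed a chloro without moving the number beyond the scatter. Compound 3 `COc1ccc(Cl)cc1-c1ccc(NC(=O)c2ccnn2C)nc1N` differs from compound 2 by methoxy in place of chloro on an aromatic carbon. Within the data shown here, no measured step matches this change, so the one known step is only a loose guide: a small shift in this assay toward a somewhat higher number is expected, a 1.2-fold higher number from compound 2 to compound 3 (0.08 log units; within the scatter). Compound 3 is therefore estimated at 1100 nM, with a range from 400 nM to 3000 nM.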

Compound 3, half-maximal inhibitory concentration: 7400 nM
Beside the measured number, compound 3's estimate is 6.7-fold (0.83 log units) below it; the measured number lies above the stated range.
By their numbers in this assay, from the lowest: compounds 1 and 2 (each within the scatter of the next); then compound 3.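

Methoxy in place of chloro on this aromatic carbon, ortho to a large group, gives an 8.0-fold higher number from compound 2 to compound 3 (0.91 log units; beyond the scatter) in this assay, which means weaker inhibition. The earlier change, removing a different chloro, stayed within the scatter, so the aryl ring does not respond alike to every change. Nothing available explains the larger step. The compounds shown leave open whether the weakening comes from losing the chloro or from gaining the methoxy. A methyl or a fluoro on this same carbon would help separate the two.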